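Notes on the aryl-ethyl variation, compound 4

The source may hold more compounds than are shown below. What is called first, only, known or untested is meant among the compounds shown, and "the series" means these compounds.

Measured in a functional assay on CHO cells for antagonist activity at Orexin/Hypocretin receptor type 1 (Homo sapiens), read by FLIPR and calcium flux; on this read-out lower numbers stand for stronger inhibition and higher numbers for weaker inhibition:
compound 1, `CCc1nc(Cl)c2n1CCN([C@@H](C(=O)NC)c1ccccc1)[C@H]2COc1ccc(C(F)(F)F)cc1`, 431 nM
compound 2, `CCc1nc(Cl)c2n1CCN([C@@H](C(=O)NC)c1ccccc1)[C@H]2CCc1ccc(C(F)(F)F)c(F)c1F`, 17 nM
compound 3, `CCc1nc(Cl)c2n1CCN([C@@H](C(=O)NC)c1ccccc1)[C@H]2CCc1cc(F)c(C(F)(F)F)cc1F`, 32 nM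

Compound 3 gives the second highest of the three numbers in this assay; its nearest neighbour is compound 2, within the scatter, while the gap to compound 1 lies beyond it. Compound 4, `CCc1nc(Cl)c2n1CCN([C@@H](C(=O)NC)c1ccccc1)[C@H]2CCc1cccc(C(F)(F)F)c1F`, carries 2-fluoro-3-(trifluoromethyl)phenyl in place of 2,5-difluoro-4-(trifluoromethyl)phenyl on a saturated chain carbon, two bonds along the chain from a saturated ring carbon. For the measured compounds named here, the one measured step that bears on this change, a shift of the fluorination pattern of the entering group, is a 1.9-fold higher number from compound 2 to compound 3 (0.27 log units; within the scatter), and it stayed within the scatter. Going by the values given here, compound 1 differs from compound 3 in the linker as well, so it offers no single-place step here. For compound 4 no shift beyond the scatter is therefore expected: the estimated step is a 1.3-fold higher number from compound 3 to compound 4 (0.10 log units; within the scatter), giving an expected 40 nM with a range from 15 nM to 110 nM.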

Compound 4, half-maximal inhibitory concentration: 16 nM
Compound 4: middle estimate off by 2.5-fold (0.40 log units), on the high side, within the range that was stated.
By their numbers in this assay, from the lowest: compounds 4, 2 and 3 (each within the scatter of the next); then compound 1.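

Replacing the ring with 2-fluoro-3-(trifluoromethyl)phenyl leaves the number within the scatter on both comparisons, a 2.0-fold lower number from compound 3 to compound 4 (0.30 log units; within the scatter) and a 1.1-fold lower number from compound 2 to compound 4 (0.03 log units; within the scatter), so this position accepts all three fluorinated aryl patterns alike. The step of a 27-fold lower number from compound 1 to compound 4 (1.43 log units; beyond the scatter) lies beyond the scatter, but it exchanges 4-(trifluoromethyl)phenoxy for 2-fluoro-3-(trifluoromethyl)benzyl, so linker and ring pattern change together. No available data explain these differences. Open, from the compounds shown here alone, is whether the trifluoromethyl group is needed on this ring, for instance against a nitrile or a plain phenyl. Also open, going by these compounds, is how a longer chain would read out in this assay.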